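This account rests on a few compounds, and the source may have more. Where it says the series, first, only, none or still open, it means among the compounds named here.

In a functional assay on UACC-62 cells (Homo sapiens) for cytotoxicity, read by sulforhodamine B assay, with a stated time of 48 h (a higher number here means a weaker inhibitor of growth, a lower number a stronger inhibitor of growth), compound 1 `ClCc1ccc(Cn2cnc3c(Cl)ncnc32)cc1` gives 33900 nM. Compound 2 `Nc1nc(Cl)c2ncn(Cc3ccc(CCl)cc3)c2n1` carries amino in place of hydrogen on an aromatic carbon and gives 8130 nM, so that a 4.2-fold lower number from compound 1 to compound 2 (0.62 log units; beyond the scatter). Compound 3 `ClCc1ccccc1Cn1cnc2c(Cl)ncnc21` is built from the same atoms as compound 1 joined differently; the difference between the two cores is not broken down here. In this assay compound 3 gives 6600 nM, the lowest number of the three, although its gap to compound 2 lies within the usual scatter. Compound 4 `Nc1nc(Cl)c2ncn(Cc3ccccc3CCl)c2n1` is not yet measured; it differs from compound 3 by amino in place of hydrogen on an aromatic carbon, the same change, at the same place, that separates compound 2 from compound 1. Because a 4.2-fold lower number from compound 1 to compound 2 (0.62 log units; beyond the scatter) was modest but beyond the scatter, a step of similar size is expected here, a 3.7-fold lower number from compound 3 to compound 4 (0.56 log units; beyond the scatter). Compound 4 is therefore estimated at 1800 nM, most likely between 700 nM and 5000 nM.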

Compound 4, concentration for total growth inhibition: 4370 nM
Compound 4: middle estimate off by 2.4-fold (0.39 log units), on the low side, and the stated range covers the measured number.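

In this assay amino in place of hydrogen on an aromatic carbon gives a 1.5-fold lower number from compound 3 to compound 4 (0.18 log units; within the scatter), so on this core the change cannot be told apart from the scatter. The step therefore did not carry over at its earlier size from one core to the other: the same change on two cores in this assay, a 4.2-fold lower number (0.62 log units; beyond the scatter) from compound 1 to compound 2 and a 1.5-fold lower number (0.18 log units; within the scatter) from compound 3 to compound 4, 2.8-fold (0.44 log units) apart, beyond the scatter of two such steps. This shows that the size of the step depends on the core in these two pairs, but it does not show why, nor what the change would do on any further core.

The compounds shown leave open what a methylamino or a hydroxyl group in the same place would give on either core. They also leave open whether either of these would follow the same difference between the two cores.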